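Cytotoxicity Outlook for an Aryl Swap on the Shared Core

The source may report more compounds than this note shows. Statements on the series, on what has been measured and on what is new or still open speak of the compounds shown alone.

In an ADME assay on HepG2 cells (Homo sapiens) for cytotoxicity, read by luminescence, CellTiter-Glo and ATP content, with a stated time of 72 h (on this read-out higher numbers stand for an effect only at larger amounts of compound and lower numbers for an effect already at smaller amounts), compound 2 `COc1cccc(CNCCCNc2ccnc3cc(Cc4cccc(C(F)(F)F)c4)ccc23)c1O` gives 1720 nM, the lowest of the two numbers measured; compound 1 `COc1cccc(CNCCCNc2ccnc3cc(Oc4ccc(Cl)cc4)ccc23)c1O` gives 5700 nM. Within the data shown here, the one measured step at this position, a 3.3-fold lower number from compound 1 to compound 2 (0.52 log units; beyond the scatter), was modest yet beyond the scatter. Compound 3 `COc1cccc(CNCCCNc2ccnc3cc(-c4ccc(C(C)(C)C)cc4)ccc23)c1O` differs from compound 2 by 4-(tert-butyl)phenyl in place of 3-(trifluoromethyl)benzyl on an aromatic carbon. Among the measured compounds shown here, no measured step covers this particular exchange, and both compounds keep one aromatic ring at the same place, so compound 3 is expected to move by a 1.1-fold higher number from compound 2 to compound 3 (0.04 log units; within the scatter), a step not beyond the scatter. Compound 3 is therefore estimated at 1900 nM, within 600 nM to 6000 nM.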

Compound 3, half-maximal effective concentration: 690 nM
Compound 3: middle estimate off by 2.8-fold (0.44 log units), on the high side, and the stated range covers the measured number.
By their numbers in this assay, from the lowest: compound 3; then compound 2; then compound 1.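

In this assay, keeping one aromatic ring at this position did not hold the number level: the exchange gave a 2.5-fold lower number from compound 2 to compound 3 (0.40 log units; beyond the scatter), so the position responds to more than the presence of that ring. Replacing 4-chlorophenoxy with 4-(tert-butyl)phenyl gave an 8.3-fold lower number from compound 1 to compound 3 (0.92 log units; beyond the scatter), placing compound 3 lowest of the three. No available evidence bears on what underlies these steps. Where a phenyl ring carrying an amine or a carboxylic acid would fall in this order remains open.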